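Hydroxy to amino on two related cores

The source may hold more compounds than are shown below. What is called first, only, known or untested is meant among the compounds shown, and "the series" means these compounds.

Compound 1 `Oc1ccc(/C=C/c2ccccc2O)cc1` and compound 3 `Nc1ccc(/C=C/c2ccccc2O)cc1` share one core; compound 2 `COc1ccccc1/C=C/c1cccc(O)c1` carries another, and the difference between the two cores is not broken down here. In a functional assay on HT-29 cells (Homo sapiens) for inhibition, read by MTT assay, with a stated time of 2 days (a higher number here means a weaker inhibitor, a lower number a stronger inhibitor), compound 1 gives 22 ug/mL, compound 3 gives 37 ug/mL and compound 2 gives 17 ug/mL. The change from compound 1 to compound 3 is amino in place of hydroxy on an aromatic carbon and moves the number by a 1.7-fold higher number from compound 1 to compound 3 (0.23 log units; within the scatter). Compound 4 `COc1ccccc1/C=C/c1cccc(N)c1` is not yet measured; it differs from compound 2 by amino in place of hydroxy on an aromatic carbon. This is the same kind of change, though not the same one: in compound 3 the entering group sits para to a group of 9 heavy atoms, in compound 4 meta to a large group. Among the measured compounds shown here, only one measured instance of the change exists, and the two compounds it joins sit within the scatter of each other, so little weight can rest on it. For compound 4 in this assay the expected step is a 1.7-fold higher number from compound 2 to compound 4 (0.23 log units; within the scatter), resting on the earlier step of a 1.7-fold higher number from compound 1 to compound 3 (0.23 log units; within the scatter). Compound 4 is therefore estimated at 29 ug/mL, with a range from 13 ug/mL to 65 ug/mL.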

Compound 4, half-maximal inhibitory concentration: 25.3 ug/mL
Beside the measured number, compound 4's estimate is 1.1-fold (0.06 log units) above it; low and high end bracket the measured number.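

In this assay, amino in place of hydroxy on an aromatic carbon gives a 1.5-fold higher number from compound 2 to compound 4 (0.17 log units; within the scatter), and this new step agrees with the earlier one on the other core: the same change on two cores in this assay, a 1.7-fold higher number (0.23 log units; within the scatter) from compound 1 to compound 3 and a 1.5-fold higher number (0.17 log units; within the scatter) from compound 2 to compound 4, 1.1-fold (0.05 log units) apart, within the scatter of two such steps. Within these two cores, then, the earlier step carries over to the core of compound 2 with no gap that can be told apart from scatter. This does not show that the change has a real effect, since each step lies within the scatter, nor does a pair of instances show how the change behaves on any further core.

Open, as far as these compounds go, is whether a group of another kind on the same aromatic carbon, such as a carboxylic acid, an acetamide or a longer alkoxy chain, would move the number beyond the scatter. Also open is how the parts of the difference between the core of compound 1 and the core of compound 2 each bear on the number, as the compounds shown do not separate them.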